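Triazolylmethyl spirooxindoles: antiproliferative readings on a liver cell line

This account rests on a few compounds, and the source may have more. Where it says the series, first, only, none or still open, it means among the compounds named here.

Measured compounds:
compound 1 `Cc1cccc(-n2nncc2CN2C(=O)C3(C(C#N)=C(N)Oc4c3c3nc5ccccc5nc3c3ccccc43)c3ccccc32)c1` — > 50000 nM
compound 2 `N#CC1=C(N)Oc2c(N)cc3nc4ccccc4nc3c2C12C(=O)N(Cc1cnnn1-c1ccccc1Cl)c1ccccc12` — 33500 nM

Compound 1 `Cc1cccc(-n2nncc2CN2C(=O)C3(C(C#N)=C(N)Oc4c3c3nc5ccccc5nc3c3ccccc43)c3ccccc32)c1` reaches only a limit of the assay in a functional assay on HepG2 cells (Homo sapiens) for antiproliferative activity, read by MTT assay, with a stated time of 48 h (a higher number here means a weaker inhibitor, a lower number a stronger inhibitor), > 50000 nM. For the measured compounds named here, compound 2 `N#CC1=C(N)Oc2c(N)cc3nc4ccccc4nc3c2C12C(=O)N(Cc1cnnn1-c1ccccc1Cl)c1ccccc12` is the only compound with a number in this assay, where compound 2 gives 33500 nM. The other value shown is the limit of > 50000 nM in this assay, at which 1 of the 2 values shown sits. Compound 2 therefore cannot be ranked against compound 1 beyond saying that it lies below that limit. Going by the values given here, no step between two measured compounds is available.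

Compound 3 `Cc1ccc(C)c(-n2nncc2CN2C(=O)C3(C(C#N)=C(N)Oc4c(N)cc5nc6ccccc6nc5c43)c3ccccc32)c1` differs from compound 2 in one place: 2,5-dimethylphenyl in place of 2-chlorophenyl on an aromatic nitrogen. Among the compounds with values here, both of the compounds measured so far are weak in this assay, and no evidence ties the aromatic group on the triazole to a shift in activity. The step from compound 2 to compound 3 is therefore expected to be small, a 1.1-fold higher number from compound 2 to compound 3 (0.05 log units; within the scatter), in no particular direction beyond the scatter. Compound 3 is expected to give about 38000 nM, within 15000 nM to 80000 nM, with a fair chance that it too ends at a limit.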

Compound 3, half-maximal inhibitory concentration: > 50000 nM
Compound 3 ended at the assay's limit; the forecaster's own chance of this, stated with the estimate: 35%; middle value at least 1.3-fold (0.11 log units) from the limit.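

In this assay, 2,5-dimethylphenyl in place of 2-chlorophenyl on this aromatic nitrogen gives an at least 1.4-fold higher number from compound 2 to compound 3 (0.17 log units; that floor lies within the scatter). This step is a floor set by a limit of the assay, so its true size cannot be read, and the floor alone does not establish a real loss; it does, however, give no sign of a gain from this change. A second compound now stands at the limit, leaving compound 2 as the only one in this pair with a numerical reading: the limit of > 50000 nM in this assay, at which 2 of the 3 values shown sit.

Still open, going by these compounds, is whether any group on this aromatic nitrogen brings the reading well clear of that limit, for example a phenyl ring carrying a methoxy group, an amine or a carboxylic acid. Also open is the effect of changes to the shared core, which the compounds shown do not isolate in a single step.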